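The compounds below may be only part of what the source reports. "The series", "measured", "known", "first", "only" and "open" are said of these compounds alone.

Measured compounds:
compound 1 `C#CCN(CCCOc1ccc2ccc(=O)oc2c1)Cc1ccccc1` — 3740 nM
compound 2 `C#CCN(CCCOc1ccc2ccc(=O)oc2c1)Cc1cccc(OC)c1` — 4590 nM

In an assay on isolated protein for inhibition of Amine oxidase [flavin-containing] B (Homo sapiens), read by fluorescence and Amplex Red, with stated times of 15 min and 20 min (on this read-out higher numbers stand for weaker inhibition and lower numbers for stronger inhibition), compound 1 gives 3740 nM and compound 2 gives 4590 nM. Within the data shown here, compound 2 holds the highest of the two numbers, but its only neighbour is compound 1, and the step of a 1.2-fold higher number from compound 1 to compound 2 (0.09 log units; within the scatter) lies within the scatter, so the two are not separated.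

Compound 3 `C#CCN(CCCOc1ccc2ccc(=O)oc2c1)Cc1cccc(F)c1` differs from compound 2 in one place: fluoro in place of methoxy on an aromatic carbon. Among the measured compounds shown here, no measured step exchanges methoxy for fluoro. For the measured compounds named here, the one step that touches this position, a 1.2-fold higher number from compound 1 to compound 2 (0.09 log units; within the scatter), shows that putting a methoxy on that carbon left the number essentially unchanged; nothing suggests that a fluoro at the same place would move the number much either way.

The step of a 1.1-fold lower number from compound 2 to compound 3 (0.06 log units; within the scatter) is therefore expected to stay within the scatter. Compound 3 is estimated at 4000 nM in this assay, with a range of 1800 nM to 9000 nM.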

Compound 3, half-maximal inhibitory concentration: 4440 nM
Estimate against measurement, compound 3: 1.1-fold (0.05 log units) below; the range from low to high includes it.
By their numbers in this assay, from the lowest: compounds 1, 3 and 2 (each within the scatter of the next).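

Fluoro in place of methoxy gives a 1.0-fold lower number from compound 2 to compound 3 (0.01 log units; within the scatter) in this assay, and fluoro in place of hydrogen gives a 1.2-fold higher number from compound 1 to compound 3 (0.07 log units; within the scatter) on the same aromatic carbon. Hydrogen, methoxy and fluoro are therefore not separated at this place, meta to a large group, even though methoxy carries two heavy atoms and a hydrogen-bond acceptor and fluoro carries one heavy atom and no acceptor. No supporting evidence bears on why these three compounds read alike.

From the compounds shown here alone, whether this flat reading holds for an amine, a carboxylic acid or a longer chain at this carbon remains open. The compounds shown also leave open whether methoxy or fluoro would read the same on another carbon of this ring.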